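Furan-2-yl to 3,4-dimethoxyphenyl: what to expect

The compounds below may be only part of what the source reports. "The series", "measured", "known", "first", "only" and "open" are said of these compounds alone.

Three compounds of the series have been run in a functional assay for inhibition, tested at 80 ug/mL; a higher number here means a stronger effect of the compound at the concentration tested, a lower number a weaker effect. Compound 1 `Cc1cc(O)c(C(C)C)cc1-c1cc(-c2ccccc2[N+](=O)[O-])c(C#N)c(=O)[nH]1` gives 35%. Compound 2 `COc1ccc(-c2cc(-c3cc(C(C)C)c(O)cc3C)[nH]c(=O)c2C#N)c(OC)c1` gives 55%, and compound 3 `Cc1cc(O)c(C(C)C)cc1-c1cc(-c2ccco2)c(C#N)c(=O)[nH]1` gives 64%, the highest of the three numbers. The gap from compound 3 to compound 2 is within the scatter, and only the gap to compound 1 lies beyond it, a number 29 percentage points higher from compound 1 to compound 3 (beyond the scatter); the same direction is seen in a number 20 percentage points higher from compound 1 to compound 2 (beyond the scatter).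

Within the data shown here, compound 4 `COc1ccc(-c2cc(-c3cc(C(C)C)c(O)cc3C)[nH]c(=O)c2C#N)cc1OC` is not yet measured. 3,4-dimethoxyphenyl in place of furan-2-yl on an aromatic carbon The one measured step that bears on this change is a number 9 percentage points higher from compound 2 to compound 3 (within the scatter), in which compound 2 carries the related 2,4-dimethoxyphenyl group; that step was within the scatter. Returning to a dimethoxyphenyl group is therefore expected to change the number by little, if anything, beyond the scatter, and the estimated step is a number 9 percentage points lower from compound 3 to compound 4 (within the scatter). For compound 4 the expected inhibition in this assay is estimated at 55%, within 40% to 70%.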

Compound 4, a percentage reported as inhibition, at one concentration (the size of the read-out at that concentration, not a potency): 58%
Compound 4: middle estimate off by 3 percentage points, on the low side; low and high end bracket the measured number.
By their numbers in this assay, from the lowest: compound 1; then compounds 2, 4 and 3 (each within the scatter of the next).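

In this assay, 3,4-dimethoxyphenyl, with 10 heavy atoms against 5 in furan-2-yl, stands on the carbon opposite the ring nitrogen with a number 6 percentage points lower from compound 3 to compound 4 (within the scatter), so at this position the larger, carbon-only six-membered ring gives no step beyond the scatter. Among these compounds, the two dimethoxyphenyl groups are not told apart, with a number 3 percentage points higher from compound 2 to compound 4 (within the scatter), whereas 2-nitrophenyl stays apart from the 3,4-dimethoxyphenyl group, with a number 23 percentage points higher from compound 1 to compound 4 (beyond the scatter), which leaves compound 1 as the only compound of the four set off from the others. No measured data here account for any of these steps.

On these data alone, whether an amine, a carboxylic acid or a longer chain on this carbon would keep the number or move it remains open. As far as these compounds go, with a read-out at a single concentration, whether compound 2, compound 3 and compound 4 would still show no clear difference in effect at other concentrations also remains open.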